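Methyl ester in place of carboxylic acid: expected potency

The source may report more compounds than this note shows. Statements on the series, on what has been measured and on what is new or still open speak of the compounds shown alone.

Three compounds share one core and differ only in the group on the carbonyl carbon. Compound 1 `NC(=O)c1cc(-c2cccc(OC(=O)NC3CCCCC3)c2)n(-c2ccccc2)n1` carries a primary amide, and in an assay on isolated protein for inhibition of Fatty-acid amide hydrolase 1 (Homo sapiens), read by fluorescence, with a stated time of 30 min (a higher number here means a weaker inhibitor, a lower number a stronger inhibitor), compound 1 gives 169 nM. Compound 2 `CCN(CC)C(=O)c1cc(-c2cccc(OC(=O)NC3CCCCC3)c2)n(-c2ccccc2)n1` carries a diethylamide, and in this assay compound 2 gives 448 nM. Compound 3 `O=C(NC1CCCCC1)Oc1cccc(-c2cc(C(=O)O)nn2-c2ccccc2)c1` carries a carboxylic acid, and in this assay compound 3 gives 2270 nM, the highest number of the three: the step of a 13-fold higher number from compound 1 to compound 3 (1.13 log units; beyond the scatter) and the step of a 5.1-fold higher number from compound 2 to compound 3 (0.70 log units; beyond the scatter) both lie beyond the scatter, as does a 2.7-fold higher number from compound 1 to compound 2 (0.42 log units; beyond the scatter).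

Compound 4 `COC(=O)c1cc(-c2cccc(OC(=O)NC3CCCCC3)c2)n(-c2ccccc2)n1` is the methyl ester of compound 3; the change is methyl in place of hydrogen on an oxygen next to a carbonyl group. Going by the values given here, no measured pair shows exactly this change, but all three measured steps alter the same carbonyl carbon, and the acid sits at the weak end by a 13-fold higher number from compound 1 to compound 3 (1.13 log units; beyond the scatter). Compound 4 is therefore expected to move back toward compounds 1 and 2, with an estimated step of a 3.8-fold lower number from compound 3 to compound 4 (0.58 log units; beyond the scatter) that is a modest drop in number. Compound 4 is estimated to give about 600 nM, within a range of 200 nM to 1800 nM.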

Compound 4, half-maximal inhibitory concentration: 18 nM
Beside the measured number, compound 4's estimate is 33-fold (1.52 log units) above it; the whole stated range lies above it.
By their numbers in this assay, from the lowest: compound 4; then compound 1; then compound 2; then compound 3.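

In this assay, the carbonyl position proves far more responsive than the two amides and the acid had indicated, for methyl in place of hydrogen on the oxygen gives a 130-fold lower number from compound 3 to compound 4 (2.10 log units; beyond the scatter) and reaches a level none of them approached. The methoxy group also outperforms both amide groups, with a 25-fold lower number from compound 2 to compound 4 (1.40 log units; beyond the scatter) and a 9.4-fold lower number from compound 1 to compound 4 (0.97 log units; beyond the scatter) marking these steps, so compound 4 is the strongest inhibitor of the four and the weak reading of compound 3 is not simply a distance from the amides. The compounds shown offer no evidence on why this small change has so large an effect.

On these data alone, whether the gain survives on the same oxygen with an ethyl group, a longer chain or a phenyl ring remains open. So does the effect of a methylamide at this carbonyl carbon, which would show how closely an amide can approach the methyl ester.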